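From 2-phenylethenyl to 3,4-dimethoxyphenyl on the saturated carbon

The source may hold more compounds than are shown below. What is called first, only, known or untested is meant among the compounds shown, and "the series" means these compounds.

Of the compounds shown here, three of the shared core have been measured in a functional assay on SF-268 cells (Homo sapiens) for antiproliferative activity, with a stated time of 48 h; on this read-out lower numbers stand for stronger inhibition of growth and higher numbers for weaker inhibition of growth. Compound 1 `Cc1cc(O)c(C2=NN(c3ccc(S(N)(=O)=O)cc3)C(c3ccccc3O)C2)cc1Cl` gives 2640 nM, compound 2 `Cc1cc(O)c(C2=NN(c3ccc(S(N)(=O)=O)cc3)C(c3ccccc3Cl)C2)cc1Cl` gives 1920 nM, and compound 3 `Cc1cc(O)c(C2=NN(c3ccc(S(N)(=O)=O)cc3)C(/C=C/c3ccccc3)C2)cc1Cl` gives 5630 nM. Compound 3 therefore stands highest of the three: the difference a 2.1-fold higher number from compound 1 to compound 3 (0.33 log units; beyond the scatter) and the difference a 2.9-fold higher number from compound 2 to compound 3 (0.47 log units; beyond the scatter) both lie beyond the scatter, whereas a 1.4-fold lower number from compound 1 to compound 2 (0.14 log units; within the scatter) does not.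

The next compound, compound 4 `COc1ccc(C2CC(c3cc(Cl)c(C)cc3O)=NN2c2ccc(S(N)(=O)=O)cc2)cc1OC`, differs from compound 3 in one place: 3,4-dimethoxyphenyl in place of 2-phenylethenyl on a saturated ring carbon. The two steps that bear on this change are those leading into compound 3, since each of them exchanged an aryl group on that saturated ring carbon for the 2-phenylethenyl group and each raised the number in this assay by a modest amount. Reversing that direction, an aryl group entering in place of 2-phenylethenyl is expected to lower the number by a comparable, modest step, though 3,4-dimethoxyphenyl is neither of the aryl groups measured so far, so the size is uncertain.

Compound 4 is accordingly expected to give about 2500 nM in this assay, within a range of 1200 nM to 5500 nM. The estimated step of a 2.3-fold lower number from compound 3 to compound 4 (0.35 log units; beyond the scatter) would bring compound 4 close to where compound 1 and compound 2 stand.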

Compound 4, concentration for 50% growth inhibition: 4740 nM
Compound 4: the middle estimate sits 1.9-fold (0.28 log units) below what was measured; the range from low to high includes it.
By their numbers in this assay, from the lowest: compounds 2, 1, 4 and 3 (each within the scatter of the next, the first and the last beyond it).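

In this assay, the exchange of 2-phenylethenyl for 3,4-dimethoxyphenyl on the saturated ring carbon leaves the read-out within the scatter (a 1.2-fold lower number from compound 3 to compound 4 (0.07 log units; within the scatter)), so an aromatic ring placed directly on that carbon does not by itself bring a compound to the level of compound 2. Among the three aryl groups measured at this position, the outcome depends on the group: 3,4-dimethoxyphenyl gives a higher number than 2-chlorophenyl (a 2.5-fold higher number from compound 2 to compound 4 (0.39 log units; beyond the scatter)) but cannot be separated from 2-hydroxyphenyl (a 1.8-fold higher number from compound 1 to compound 4 (0.25 log units; within the scatter)). No measurement available here explains these differences.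

The three aryl groups differ in both the identity and the placement of their substituents, so these compounds cannot show which of the two governs the read-out at this carbon. A 2-methoxyphenyl or 4-methoxyphenyl group would help to separate those two factors, while a 2-phenylethyl chain or a 4-(dimethylamino)phenyl group would extend the comparison beyond the groups shown.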